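The source may hold more compounds than are shown below. What is called first, only, known or untested is meant among the compounds shown, and "the series" means these compounds.

Compound 3 `CCN(CC)C(=O)Cc1c(-c2ccc(OCc3ccccc3F)cc2)nn2c(C)cc(C)nc12` sits lowest of the three numbers in an assay on isolated protein (kidney, strain Wistar) for displacement of a labelled ligand from Translocator protein (Rattus norvegicus), read by scintillation counting, with a stated time of 90 min (a higher number here means a weaker inhibitor, a lower number a stronger inhibitor), where compound 3 gives 0.31 nM. Compound 1 `CCN(CC)C(=O)Cc1c(-c2ccc(OC(C)C)cc2)nn2c(C)cc(C)nc12` gives 2.2 nM and compound 2 `CCN(CC)C(=O)Cc1c(-c2ccc(OCC3CCCCC3)cc2)nn2c(C)cc(C)nc12` gives 3.6 nM; the steps of a 7.1-fold lower number from compound 1 to compound 3 (0.85 log units; beyond the scatter) and a 12-fold lower number from compound 2 to compound 3 (1.06 log units; beyond the scatter) both lie beyond the scatter, while a 1.6-fold higher number from compound 1 to compound 2 (0.21 log units; within the scatter) does not. Compound 4 `CCN(CC)C(=O)Cc1c(-c2ccc(OCc3ccc(F)cc3)cc2)nn2c(C)cc(C)nc12` differs from compound 3 only by 4-fluorophenyl in place of 2-fluorophenyl on a saturated chain carbon bound to an oxygen on an aromatic ring. Going by the values given here, no measured step moves the fluorine within the same ring: the two steps that reach compound 3 exchange the whole group on the oxygen, so they single out the fluorobenzyl ether but say nothing about where its fluorine stands. The estimate for compound 4 is therefore a step of a 1.5-fold higher number from compound 3 to compound 4 (0.16 log units; within the scatter), not beyond the scatter. Compound 4 is expected in this assay at 0.45 nM, range 0.15 nM to 1.5 nM.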

Compound 4, inhibition constant: 0.77 nM
Beside the measured number, compound 4's estimate is 1.7-fold (0.23 log units) below it; low and high end bracket the measured number.
By their numbers in this assay, from the lowest: compound 3; then compound 4; then compounds 1 and 2 (each within the scatter of the next).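

In this assay, the position of the fluorine on the benzyl ring counts at this place (a 2.5-fold higher number from compound 3 to compound 4 (0.40 log units; beyond the scatter)), so 2-fluorophenyl and 4-fluorophenyl are not interchangeable on the saturated chain carbon bound to the oxygen. The gain of the fluorobenzyl ethers over the other groups on the oxygen holds for both fluorine placements (a 2.9-fold lower number from compound 1 to compound 4 (0.46 log units; beyond the scatter); a 4.7-fold lower number from compound 2 to compound 4 (0.67 log units; beyond the scatter)). Nothing measured here accounts for the preference for 2-fluorobenzyl.

Whether the fluorine contributes at all stays open, since a plain benzyl group on the same oxygen is absent from the compounds shown. A chlorobenzyl group would show whether the preference is specific to fluorine.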